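A few compounds are considered here, and "the series" means these few. Any claim that something is new, unique, unknown or untested is made for them only; others in the source may bear on it.

In a functional assay on SW-620 cells (Homo sapiens) for cytotoxicity, read by MTT assay, with a stated time of 48 h (on this read-out higher numbers stand for weaker inhibition and lower numbers for stronger inhibition), compound 1 `CCCCCCCCNC(=O)[C@@H](NC(=O)c1ccco1)[C@@H](C)O` gives 200000 nM; compound 2 `CCCCCCCCNC(=O)[C@@H](NC(=O)c1cccs1)[C@@H](C)O` gives 136000 nM; compound 3 `CCCCCCCCCCCCNC(=O)[C@@H](NC(=O)c1ccco1)[C@@H](C)O` gives 87500 nM.

Compound 4 `CCCCCCCCCCCCNC(=O)[C@@H](NC(=O)c1cccs1)[C@@H](C)O` has not yet been measured in this assay. The core of compound 3 differs from the core of compound 1 by butyl in place of hydrogen on a saturated chain carbon, eight bonds along the chain from an amide-type nitrogen, a change that produced a 2.3-fold lower number from compound 1 to compound 3 (0.36 log units; beyond the scatter). Compound 4 is built on the core of compound 3 and differs from it by thiophen-2-yl in place of furan-2-yl on a carbonyl carbon. The same change, (thiophen-2-yl in place of furan-2-yl on a carbonyl carbon), was made on the core of compound 1 and there gave a 1.5-fold lower number from compound 1 to compound 2 (0.17 log units; within the scatter). That step lay within the scatter. The expected step for compound 4 is therefore a 1.5-fold lower number from compound 3 to compound 4 (0.18 log units; within the scatter), likewise within the scatter. The estimate for compound 4 in this assay is 58000 nM, with a likely range from 30000 nM to 120000 nM.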

Compound 4, half-maximal inhibitory concentration: 29200 nM
Beside the measured number, compound 4's estimate is 2.0-fold (0.30 log units) above it; the measured number lies below the stated range.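

In this assay, thiophen-2-yl in place of furan-2-yl gave a 3.0-fold lower number from compound 3 to compound 4 (0.48 log units; beyond the scatter), and this step does not differ, beyond the scatter, from the same change on the other core: the same change on two cores in this assay, a 1.5-fold lower number (0.17 log units; within the scatter) from compound 1 to compound 2 and a 3.0-fold lower number (0.48 log units; beyond the scatter) from compound 3 to compound 4, 2.0-fold (0.31 log units) apart, within the scatter of two such steps. Butyl in place of hydrogen on the saturated chain gave a 4.7-fold lower number from compound 2 to compound 4 (0.67 log units; beyond the scatter), and this step also matches its counterpart within the scatter: the same change on two cores in this assay, a 2.3-fold lower number (0.36 log units; beyond the scatter) from compound 1 to compound 3 and a 4.7-fold lower number (0.67 log units; beyond the scatter) from compound 2 to compound 4, 2.0-fold (0.31 log units) apart, within the scatter of two such steps. Each change therefore carried over between these two cores, but two pairs of steps cannot show that it would carry to any other core.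

The compounds shown leave open whether a phenyl group on the carbonyl carbon would fit the same picture. They also leave open whether a longer chain would lower the number further.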